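The compounds below may be only part of what the source reports. "The series", "measured", "known", "first", "only" and "open" are said of these compounds alone.

Measured so far:
- compound 1 `CCCNC(=O)c1ccc(Oc2nc(-c3c(C)noc3C)cnc2N)cc1`: 47800 nM
- compound 2 `Cc1noc(C)c1-c1cnc(N)c(Oc2ccc(C(=O)Nc3cccc(Cl)c3)cc2)n1`: 11500 nM

In a functional assay on U-87MG ATCC cells for inhibition, with U-87 MG (Homo sapiens) as the target, read by MTT assay, with a stated time of 72 h (on this read-out lower numbers stand for stronger inhibition and higher numbers for weaker inhibition), compound 2 has the lower of the two numbers at 11500 nM, and compound 1 gives 47800 nM. The next compound is compound 3 `Cc1noc(C)c1-c1cnc(N)c(Oc2ccc(C(=O)Nc3ncccc3Cl)cc2)n1`, which puts 3-chloropyridin-2-yl in place of 3-chlorophenyl on an amide-type nitrogen.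

Among the compounds with values here, only one measured step bears on this change. It is a 4.2-fold lower number from compound 1 to compound 2 (0.62 log units; beyond the scatter), a modest step that swapped propyl for 3-chlorophenyl on the same amide-type nitrogen. Within the data shown here, no measured pair tests a change from a carbon-only ring to a ring with a hetero atom. That modest step replaced a chain with a ring, whereas here one ring replaces another, so no step beyond the scatter is expected in this assay. The expected step is a 1.2-fold higher number from compound 2 to compound 3 (0.09 log units; within the scatter). Compound 3 is estimated at 14000 nM, with an expected range of 5000 nM to 40000 nM.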

Compound 3, half-maximal inhibitory concentration: 45600 nM
Compound 3: middle estimate off by 3.3-fold (0.51 log units), on the low side, outside the stated range (above it).
By their numbers in this assay, from the lowest: compound 2; then compounds 3 and 1 (each within the scatter of the next).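

In this assay, the amide-type nitrogen proves sensitive to a single change within the ring: a 4.0-fold higher number from compound 2 to compound 3 (0.60 log units; beyond the scatter), with 3-chloropyridin-2-yl bringing a ring nitrogen and a hydrogen-bond acceptor that 3-chlorophenyl lacks. Having a chlorinated aromatic ring at this nitrogen is therefore not enough on its own: a 4.2-fold lower number from compound 1 to compound 2 (0.62 log units; beyond the scatter), yet a 1.0-fold lower number from compound 1 to compound 3 (0.02 log units; within the scatter), so compound 3 goes against any reading that favours rings over propyl here. No measurement available accounts for the difference between these two rings.

From the compounds shown here alone, it remains open whether the chlorine contributes to the number of compound 2, which plain phenyl or pyridin-2-yl groups would address. Also open, going by these compounds, is how an amine or a carboxylic acid on the ring, or a longer chain such as hexyl in place of propyl, would read in this assay.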